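A few compounds are considered here, and "the series" means these few. Any claim that something is new, unique, unknown or untested is made for them only; others in the source may bear on it.

Compound 2, drawn as `Cc1c(NCC(C)C)c(=O)n(-c2ccccc2)c(=O)n1C`, stands at the lower end of what has been measured here. In a physicochemical assay for lipophilicity (a lower number here means a more polar compound, a higher number a more lipophilic compound), compound 2 gives 1.48, the lowest of the two numbers in hand. Its nearest neighbour is compound 1, drawn as `C=CCN(CC=C)c1c(C)n(-c2ccccc2)c(=O)n(C)c1=O`, which in this assay gives 2.59, a difference that lies well beyond the scatter of repeated measurements. Compound 1 carries two allyl chains on its amine nitrogen and no hydrogen on that nitrogen, whereas compound 2 carries a single isobutyl chain and keeps one hydrogen there.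

The step from compound 2 to compound 3, drawn as `Cc1c(N2CCCCC2)c(=O)n(-c2ccccc2)c(=O)n1C`, is a single change: piperidin-1-yl in place of isobutylamino on an aromatic carbon. The amine hydrogen that could act as a hydrogen-bond donor disappears, and the chain closes into a ring with one more heavy atom.

Compound 3 has not yet been measured in this assay. Its value is estimated at 2.3, within a range of 1.8 to 2.8. This expectation means a step of a number 0.82 log units higher from compound 2 to compound 3 (beyond the scatter), upward and beyond the scatter, resting on the gap between compound 2 at 1.48 and compound 1 at 2.59.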

Compound 3, partition coefficient: 2.76
For compound 3 the middle estimate is 0.46 log units below the measured one, and the stated range covers the measured number.
By their numbers in this assay, from the lowest: compound 2; then compounds 1 and 3 (each within the scatter of the next).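

Within the data shown here, the step from isobutylamino to piperidin-1-yl is the first reading at this position with the rest of the molecule held constant, since compounds 1 and 2 differ in more than one place. In this assay, this single change on the aromatic carbon gives a number 1.28 log units higher from compound 2 to compound 3 (beyond the scatter), so the group at this position alone can move the number well beyond the scatter. The change does several things at once, though: it removes the hydrogen-bond donor, closes the chain into a six-membered non-aromatic ring and alters the heavy-atom count, and nothing available here links the step to any one of these or offers a measured explanation for it.

Going by these compounds, it therefore remains open whether the loss of the amine hydrogen or the closing of the ring matters more, a question that an open-chain diethylamino group at the same carbon, with no amine hydrogen and no ring, could help to separate. On these data alone, how far the step holds for other rings is also open, for instance with pyrrolidin-1-yl or with morpholin-4-yl, which carries an oxygen atom in its ring.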